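This account rests on a few compounds, and the source may have more. Where it says the series, first, only, none or still open, it means among the compounds named here.

Measured so far:
compound 1 `Nc1nc(Cl)c2ncn(Cc3ccc(CCl)cc3)c2n1` — 67600 nM
compound 2 `ClCc1cccc(Cn2cnc3c(Cl)nc(Cl)nc32)c1` — > 100000 nM
compound 3 `ClCc1ccc(Cn2cnc3c(Cl)nc(Cl)nc32)cc1` — 7590 nM

In a functional assay on HCT-15 cells (Homo sapiens) for cytotoxicity, read by sulforhodamine B assay, with a stated time of 48 h (a higher number here means that more compound is tolerated, a lower number that less compound is tolerated), compound 3 gives 7590 nM. Compound 1 gives 67600 nM. The change amino in place of chloro on an aromatic carbon made an 8.9-fold higher number from compound 3 to compound 1 (0.95 log units; beyond the scatter). For compound 2 the assay reports only a limit, > 100000 nM; this is the limit of > 100000 nM in this assay, at which 1 of the 3 values shown sits. The difference between the cores of compound 2 and compound 3 is not broken down here.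

Compound 4 `Nc1nc(Cl)c2ncn(Cc3cccc(CCl)c3)c2n1` is still to be measured. It differs from compound 2 by amino in place of chloro on an aromatic carbon, the same change, at the same place, as that from compound 3 to compound 1. Since the value of compound 2 is a limit and the earlier step raised the number, compound 4 is expected to remain at or past the limit, with a step that the limit leaves unreadable from compound 2 to compound 4 beside the earlier one. The estimate for compound 4 is 300000 nM, between 100000 nM and 1000000 nM.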

Compound 4, concentration lethal to 50% of the cells: 33100 nM
For compound 4 the middle estimate is 9.1-fold (0.96 log units) above the measured one; the measured number lies below the stated range.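

In this assay, amino in place of chloro on an aromatic carbon gave an at least 3.0-fold lower number from compound 2 to compound 4 (0.48 log units; beyond the scatter), so the direction of the change did not carry from one core to the other: the same change on two cores in this assay, an 8.9-fold higher number (0.95 log units; beyond the scatter) from compound 3 to compound 1 and an at least 3.0-fold lower number (0.48 log units; beyond the scatter) from compound 2 to compound 4, at least 26-fold (1.42 log units) apart, beyond the scatter of two such steps. Compound 2 is held only as a limit, > 100000 nM, so the size of this step is a bound and not a number. Two pairs show that the outcome of this change depends on the core here, but they give neither a rule for other cores nor a reason for the difference.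

As far as these compounds go, whether other groups on the same aromatic carbon, such as methoxy or dimethylamino, also split by core stays open. Also open, from the compounds shown here alone, is how either core responds in other cell lines.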